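The compounds below may be only part of what the source reports. "The series", "measured", "known", "first", "only" and "open" are said of these compounds alone.

Measured so far:
compound 1 `CCOCCOC(=O)C(=O)Nc1nc(-c2cc(Cl)no2)cs1`: 6 mg/kg
compound 2 `CC(C)(C)OC(=O)C(=O)Nc1nc(-c2cc(-c3ccccc3)no2)cs1`: 9 mg/kg

In a functional assay on the whole organism with Rattus norvegicus as the target (on this read-out lower numbers stand for an effect already at smaller amounts and higher numbers for an effect only at larger amounts of compound), compound 1 gives 6 mg/kg, the smaller of the two numbers shown, while compound 2 gives 9 mg/kg, a gap that lies within the scatter. Compound 3 `CCOCCOC(=O)C(=O)Nc1nc(-c2cc(-c3c(F)cccc3Cl)no2)cs1` differs from compound 1 by 2-chloro-6-fluorophenyl in place of chloro on an aromatic carbon. For the measured compounds named here, no step between measured compounds informs this change, so nothing beyond the scatter is expected in this assay, in either direction. Compound 3 is estimated at 7 mg/kg, with a range of 3 mg/kg to 16 mg/kg; the expected step is a 1.2-fold higher number from compound 1 to compound 3 (0.07 log units; within the scatter).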

Compound 3, dose for half-maximal effect: 1.1 mg/kg
Compound 3: the middle estimate sits 6.4-fold (0.80 log units) above what was measured; measured number below the stated range.
By their numbers in this assay, from the lowest: compound 3; then compounds 1 and 2 (each within the scatter of the next).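

In this assay, for the compounds shown here, 2-chloro-6-fluorophenyl in place of chloro gives a 5.5-fold lower number from compound 1 to compound 3 (0.74 log units; beyond the scatter), the first step beyond the scatter. This aromatic carbon next to the ring nitrogen therefore accepts a much larger ring-bearing group without the number rising, and the number in fact falls. No evidence on the cause of this step is at hand. Still open, going by these compounds, is whether the phenyl ring alone or its chloro and fluoro substituents carry the step, and how an amine or a methoxy group on this carbon would read.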